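Sulfonyl substituent variation in the thiourea series

This account rests on a few compounds, and the source may have more. Where it says the series, first, only, none or still open, it means among the compounds named here.

Compound 1 `CCCS(=O)(=O)Nc1ccc(C/N=C(\S)NCc2ccc(C(C)(C)C)cc2)cc1` gives 4500 nM in a functional assay for antagonist activity at Vanilloid receptor (Rattus norvegicus); a higher number here means a weaker inhibitor, a lower number a stronger inhibitor. Compound 2 `CC(C)(C)c1ccc(C/N=C(\S)NCc2ccc(NS(=O)(=O)C(F)(F)F)cc2)cc1` gives 12400 nM, and compound 3 `CC(C)(C)c1ccc(C/N=C(\S)NCc2ccc(NS(=O)(=O)Cc3ccccc3)cc2)cc1` gives 1500 nM. Compound 1 therefore stands second highest of the three numbers, with compound 2 above it and compound 3 below it, both gaps beyond the scatter. Among the measured compounds shown here, the only single-point step among the measured compounds is an 8.3-fold lower number from compound 2 to compound 3 (0.92 log units; beyond the scatter), a change on the sulfonyl sulfur. Compound 4 `CN(C)S(=O)(=O)Nc1ccc(C/N=C(\S)NCc2ccc(C(C)(C)C)cc2)cc1`, not yet measured, differs from compound 1 by dimethylamino in place of propyl on a sulfonyl sulfur. For the measured compounds named here, this change sits on the same sulfonyl sulfur as the step from compound 2 to compound 3, but it exchanges groups of like size as counted, and no measured pair sets propyl against dimethylamino, so that step shows only that this position can shift the read-out modestly; no direction can be read from the numbers. For compound 4 the expected step is a 1.1-fold lower number from compound 1 to compound 4 (0.05 log units; within the scatter), that is, none beyond the scatter. The estimate for compound 4 is 4000 nM, with a range from 1500 nM to 11000 nM.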

Compound 4, half-maximal inhibitory concentration: 14600 nM
The estimate for compound 4 lay 3.7-fold (0.56 log units) below the measured number, and the stated range ends below it.
By their numbers in this assay, from the lowest: compound 3; then compound 1; then compounds 2 and 4 (each within the scatter of the next).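

In this assay, dimethylamino in place of propyl on a sulfonyl sulfur gives a 3.2-fold higher number from compound 1 to compound 4 (0.51 log units; beyond the scatter). The position therefore responds even when the entering and leaving groups have the same count of heavy atoms and neither carries a ring, whereas the earlier step, an 8.3-fold lower number from compound 2 to compound 3 (0.92 log units; beyond the scatter), set benzyl against trifluoromethyl. Here the count differs only in that nitrogen takes the place of one carbon, and no measurement at hand bears on why the number moves.

Open, from the compounds shown here alone, is whether the nitrogen itself matters or the branched shape of dimethylamino, which a branched carbon group such as isopropyl would help to separate. Also open, going by these compounds, is how a cyclic amine such as morpholine, or a longer chain such as butyl, on the sulfonyl sulfur compares with compound 3 at 1500 nM.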